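Swapping a Furan for a Fluoromethoxyphenyl: Permeability Outlook

The source may hold more compounds than are shown below. What is called first, only, known or untested is meant among the compounds shown, and "the series" means these compounds.

Compound 1, `CN(C)c1cccc(Oc2ccc3c(NCCCNCc4ccco4)ccnc3c2)c1`, gives 317 10^-6 cm/s in an ADME assay for permeability, using PAMPA, with a stated time of 30 min, at pH 7.4; on this read-out lower numbers stand for lower permeability and higher numbers for higher permeability. Compound 2, `COc1ccc(F)cc1CNCCCNc1ccnc2cc(Oc3cccc(N(C)C)c3)ccc12`, gives 317 10^-6 cm/s in this assay. Compound 3, `COc1ccc(-c2ccc3c(NCCCNCc4ccco4)ccnc3c2)cc1`, gives 237 10^-6 cm/s in this assay.

Compound 4, `COc1ccc(-c2ccc3c(NCCCNCc4cc(F)ccc4OC)ccnc3c2)cc1`, is not yet measured. It differs from compound 3 by 5-fluoro-2-methoxyphenyl in place of furan-2-yl on a saturated chain carbon bound to an amine nitrogen. The same change, at the same place, is already seen between compound 1 and compound 2, (5-fluoro-2-methoxyphenyl in place of furan-2-yl on a saturated chain carbon bound to an amine nitrogen), where the step was no change at the digits printed from compound 1 to compound 2 (within the scatter). The two cores differ by 4-methoxyphenyl in place of 3-(dimethylamino)phenoxy on an aromatic carbon, and that change gave a 1.3-fold lower number from compound 1 to compound 3 (0.13 log units; within the scatter). All three values sit close together, so nothing here points to a shift.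

Because the earlier step was no change at the digits printed from compound 1 to compound 2 (within the scatter), the expected step for compound 4 is a 1.0-fold higher number from compound 3 to compound 4 (0.01 log units; within the scatter). Compound 4 is therefore estimated at 240 10^-6 cm/s in this assay, expected between 150 10^-6 cm/s and 380 10^-6 cm/s.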

Compound 4, apparent permeability in the ADME assay: 237 10^-6 cm/s
Estimate against measurement, compound 4: 1.0-fold (0.01 log units) above, and the stated range covers the measured number.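

In the ADME assay compound 4 gives 237 10^-6 cm/s, and 5-fluoro-2-methoxyphenyl in place of furan-2-yl gives no change at the digits printed from compound 3 to compound 4 (within the scatter), which matches the same change on the core of compound 1: the same change on two cores in the ADME assay, no change at the digits printed (within the scatter) from compound 1 to compound 2 and no change at the digits printed (within the scatter) from compound 3 to compound 4, 1.0-fold (0.00 log units) apart, within the scatter of two such steps The change of core, 4-methoxyphenyl in place of 3-(dimethylamino)phenoxy, also reads the same with either group on the chain, with a 1.3-fold lower number from compound 2 to compound 4 (0.13 log units; within the scatter): the same change on two cores in the ADME assay, a 1.3-fold lower number (0.13 log units; within the scatter) from compound 1 to compound 3 and a 1.3-fold lower number (0.13 log units; within the scatter) from compound 2 to compound 4, 1.0-fold (0.00 log units) apart, within the scatter of two such steps This shows that the two changes combine without surprise on these two cores, but none of these steps lies beyond the scatter, so it does not show that a larger effect would carry over, or that the same would hold on other cores.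

Among the compounds shown here, in a physicochemical assay for solubility, with a stated time of 18 h, at pH 7.4 (a lower number here means a less soluble compound, a higher number a more soluble compound), the swap is seen only on one core: compound 3 gives 32000 nM and compound 4 gives 32000 nM, with no change at the digits printed from compound 3 to compound 4 (within the scatter). Left open is how a carboxylic acid or a longer chain in place of 5-fluoro-2-methoxyphenyl would read in either assay.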